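The source may hold more compounds than are shown below. What is called first, only, known or untested is meant among the compounds shown, and "the series" means these compounds.

In a physicochemical assay for solubility, read by chemiluminescence, measured as kinetic solubility (on this read-out lower numbers stand for lower solubility and higher numbers for higher solubility), none of the three measured compounds gives a plain number. Compound 1 (`CC(=O)NCc1cccc(Cn2nc(NS(=O)(=O)c3ccc(Cl)s3)c3c(O)cccc32)c1`) reads >= 166 ug/mL, which is a limit. Compound 2 (`CC(=O)NCc1cccc(Cn2nc(NS(=O)(=O)c3ccc(Cl)s3)c3c(C(F)F)cccc32)c1`) reads >= 188 ug/mL, also a limit. Compound 3 (`COc1cccc2c1c(NS(=O)(=O)c1ccc(Cl)s1)nn2Cc1cccc(CNC(=O)C2COC2)c1`) reads >= 173 ug/mL, again a limit, like both other values. Compound 4 (`COc1cccc2c1c(NS(=O)(=O)c1ccc(Cl)s1)nn2Cc1cccc(CNC(=O)C(C)(C)N)c1`) differs from compound 3 in one place: 1-amino-1-methylethyl in place of oxetan-3-yl on a carbonyl carbon. Among the compounds with values here, the only measured step, a step that the two limits leave unreadable from compound 1 to compound 2, lies elsewhere on the structure and has no readable size, so it offers no measure for this change. The expected step is a step that the limit leaves unreadable from compound 3 to compound 4, with nothing beyond the scatter anticipated in either direction. For compound 4 the estimated value is 175 ug/mL, expected to fall between 90 ug/mL and 210 ug/mL.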

Compound 4, solubility: >= 180 ug/mL
Compound 4 ended at the assay's limit (the forecaster's own chance of this, stated with the estimate: 70%); middle value at least 1.0-fold (0.01 log units) away from the limit.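

Compound 3 and compound 4 both read as limits in this assay, and the step between them cannot be read. The compounds shown leave open whether 1-amino-1-methylethyl in place of oxetan-3-yl on a carbonyl carbon changes this read-out at all.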